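Exchanging a Group on Compound 1

The source may hold more compounds than are shown below. What is called first, only, known or untested is meant among the compounds shown, and "the series" means these compounds.

Compound 1 `COC1=C(OC)[C@H](OC(C)=O)[C@H](C/C=C(\C)CC/C=C(\C)C[C@H](O)C=C(C)C)[C@@H](C)C1=O` gives 20700 nM in a functional assay on A549 cells (Homo sapiens) for inhibition, read by sulforhodamine B assay, with a stated time of 48 h; on this read-out higher numbers stand for weaker inhibition of growth and lower numbers for stronger inhibition of growth.
Compound 3 `COC1=C(OC)[C@H](O)[C@H](C/C=C(\C)CC/C=C(\C)C[C@H](O)C=C(C)C)[C@@H](C)C1=O` gives 9600 nM in this assay.
Compound 2 `COC1=C[C@H](O)[C@H](C/C=C(\C)CC/C=C(\C)C[C@H](O)/C=C(\C)CO)[C@@H](C)C1=O` gives only a limit of the assay, > 30000 nM, in this assay.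

Among the two plain numbers, compound 1 stands at the higher one, meaning the weaker growth inhibition; its nearest neighbour is compound 3, reached by a 2.2-fold lower number from compound 1 to compound 3 (0.33 log units; beyond the scatter), a modest gain from putting hydrogen in place of acetyl on an oxygen on a saturated carbon.

Compound 4 `COC1=C(OC)[C@H](OC(C)=O)[C@H](C/C=C(\C)CC/C=C(\C)C[C@H](O)C[C@@H](C)C(O)O)[C@@H](C)C1=O` differs from compound 1 by a group of 6 heavy atoms (4 carbon, 2 oxygen; no ring) in place of a group of 4 heavy atoms (4 carbon; no ring), on a saturated chain carbon bound to an oxygen on a saturated carbon and a saturated chain carbon. Among the measured compounds shown here, the single measured step, a 2.2-fold lower number from compound 1 to compound 3 (0.33 log units; beyond the scatter), touches a different part of the shared core and leaves the group that changes here untouched, so no measured step speaks to this exchange. With nothing to point either way, the step into compound 4 is expected to stay within the scatter of repeated measurements in this assay, while the uncertainty around that expectation is wide.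

Compound 4 is therefore estimated to give about 25000 nM, with a likely range from 9000 nM to 60000 nM. This estimate corresponds to a 1.2-fold higher number from compound 1 to compound 4 (0.08 log units; within the scatter).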

Compound 4, concentration for 50% growth inhibition: 15400 nM
The estimate for compound 4 lay 1.6-fold (0.21 log units) above the measured number; low and high end bracket the measured number.
By their numbers in this assay, from the lowest: compounds 3, 4 and 1 (each within the scatter of the next, the first and the last beyond it). At a limit, above all of these: compound 2.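

In this assay, the step at this end of the chain is small: swapping the 2-methylprop-1-en-1-yl group for a larger group without a common name gives a 1.3-fold lower number from compound 1 to compound 4 (0.13 log units; within the scatter). Among the compounds shown here, the earlier step changed a different part of the shared core, so this is the first reading at this saturated chain carbon, and it shows that a group with 2 hydrogen-bond donors, 2 hydrogen-bond acceptors and 1 defined stereocentre can replace one with none of these and no double bond is needed there for the number to hold within the scatter. The compounds shown offer no measured explanation for why so little changes.

Going by these compounds, whether an amine, a carboxylic acid or a longer chain at this place would move the number beyond the scatter remains open. Also open, on these data alone, is whether the same exchange would behave alike on compound 3.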